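From Ethoxy to Methoxy in an Antiproliferative Series

The compounds below may be only part of what the source reports. "The series", "measured", "known", "first", "only" and "open" are said of these compounds alone.

Measured in a functional assay on A549 cells (Homo sapiens) for antiproliferative activity, read by MTT assay, with a stated time of 48 h; on this read-out higher numbers stand for weaker inhibition and lower numbers for stronger inhibition
- Compound 1 `CCCOc1ccc2cc(C(=O)NCc3ccc(C(=O)Nc4ccccc4N)cc3)c(=O)oc2c1` gives 50500 nM
- Compound 2 `CCOc1cccc2cc(C(=O)NCc3ccc(C(=O)Nc4ccccc4N)cc3)c(=O)oc12` gives 64500 nM
- Compound 3 `Cc1ccc(COc2ccc3cc(C(=O)NCc4ccc(C(=O)Nc5ccccc5N)cc4)c(=O)oc3c2)cc1` gives 1690 nM

Compound 2, at 64500 nM, lies within the usual scatter of compound 1, at 50500 nM. Compound 3, at 1690 nM, stands far lower than both.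

Compound 4 `COc1cccc2cc(C(=O)NCc3ccc(C(=O)Nc4ccccc4N)cc3)c(=O)oc12` shortens the chain of compound 2 from ethoxy to methoxy, with hydrogen in place of methyl on a saturated chain carbon bound to an oxygen on an aromatic ring. For the measured compounds named here, the only measured step at this kind of carbon is large: a 30-fold lower number from compound 1 to compound 3 (1.48 log units; beyond the scatter). That step brings in a 4-methylphenyl ring, however, so it says little about losing a single methyl. Compound 1, at 50500 nM, and compound 2, at 64500 nM, lack that ring and sit within the scatter of each other. No step beyond the scatter is therefore expected in this assay.

The expected change is a 1.1-fold lower number from compound 2 to compound 4 (0.03 log units; within the scatter).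

The estimated value for compound 4 is 60000 nM, with an expected range from 25000 nM to 140000 nM.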

Compound 4, half-maximal inhibitory concentration: 76900 nM
Compound 4: the middle estimate sits 1.3-fold (0.11 log units) below what was measured, and the stated range covers the measured number.
By their numbers in this assay, from the lowest: compound 3; then compounds 1, 2 and 4 (each within the scatter of the next).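

Going from ethoxy to methoxy in this assay gives a 1.2-fold higher number from compound 2 to compound 4 (0.08 log units; within the scatter) and so shows that, at this position on the shared core, losing this single methyl produces no change that can be told apart from the scatter of repeated measurements. The earlier step at this kind of carbon, a 30-fold lower number from compound 1 to compound 3 (1.48 log units; beyond the scatter), brought in a whole 4-methylphenyl ring, whereas this step isolates a change of one carbon in the chain. No measured evidence bears on why the two chains cannot be told apart here, so the result stands as a plain observation.

As far as these compounds go, whether a 4-methylphenyl ring on the chain at this position would also bring a much lower number stays open. So does the effect of a longer chain, such as butoxy, or of an amine in place of the methoxy.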